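Adding a hydroxy group to the benzylamine side chain

The compounds below may be only part of what the source reports. "The series", "measured", "known", "first", "only" and "open" are said of these compounds alone.

Compound 1 `Cc1cccc(CNc2ncnc3c2ncn3[C@@H]2O[C@H](CO)[C@@H](O)[C@H]2O)c1` was tested in a functional assay on G-361 cells (Homo sapiens) for antiproliferative activity, with a stated time of 72 h; on this read-out higher numbers stand for weaker inhibition and lower numbers for stronger inhibition. In this assay compound 1 gives only a limit of the assay, > 166000 nM. Two further compounds share its core and differ from it only in the aryl group on the saturated chain carbon bound to a nitrogen on an aromatic ring. Compound 2 `OC[C@H]1O[C@@H](n2cnc3c(NCc4ccc(F)cc4F)ncnc32)[C@H](O)[C@@H]1O` also gives a limit of the assay in this assay, > 166000 nM. Compound 3 `OC[C@H]1O[C@@H](n2cnc3c(NCc4c(F)ccc(F)c4F)ncnc32)[C@H](O)[C@@H]1O` likewise gives a limit of the assay in this assay, > 166000 nM. The measured steps a step that the two limits leave unreadable from compound 1 to compound 2, a step that the two limits leave unreadable from compound 1 to compound 3 and a step that the two limits leave unreadable from compound 2 to compound 3 have no readable size; all three values sit at the limit of > 166000 nM in this assay, at which 3 of the 3 values shown sit.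

Compound 4 `Cc1ccc(O)c(CNc2ncnc3c2ncn3[C@@H]2O[C@H](CO)[C@@H](O)[C@H]2O)c1` differs from compound 1 by hydroxy in place of hydrogen on an aromatic carbon. Within the data shown here, none of the measured steps concerns a change of this kind, and the measured steps that exist show no size at all, so the available numbers offer no readable direction for the new change. Compound 4 is therefore expected to give a value of 200000 nM in this assay, with an estimated range from 90000 nM to 500000 nM. The step this estimate implies, a step that the limit leaves unreadable from compound 1 to compound 4, is expected to leave the value at the limit of the assay, with no readable change.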

Compound 4, half-maximal inhibitory concentration: > 166000 nM
Compound 4 ended at the assay's limit (the forecaster's own chance of this, stated with the estimate: 80%); the middle value does not contradict the limit.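

In this assay compound 4 gives only a limit of the assay, > 166000 nM. Among these compounds, its steps from compound 1, compound 2 and compound 3 therefore cannot be read, so no new step emerges. The compounds shown leave open whether hydroxy in place of hydrogen changes the value at all, and how these aryl groups rank: the limit of > 166000 nM in this assay, at which 4 of the 4 values shown sit.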